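Swapping the Second Aryl Ring in Acetylated Pyrazoline Analogues

This account rests on a few compounds, and the source may have more. Where it says the series, first, only, none or still open, it means among the compounds named here.

Compound 1 `COc1cc(C(=O)N/N=C/c2cccc(F)c2)cc(OC)c1OC`: 44.8%
Compound 2 `COc1cc(C2=NN(C(C)=O)C(c3cccc(OC)c3OC)O2)cc(OC)c1OC`: 17.5%
Compound 3 `COc1cc(C2=NN(C(C)=O)C(c3cc(OC)c(OC)c(OC)c3)O2)cc(OC)c1OC`: -1.4%

These three compounds were tested in a functional assay on BGC-823 cells (Homo sapiens) for antiproliferative activity, read by MTT assay, tested at 5 uM; on this read-out higher numbers stand for a stronger effect at the one concentration tested and lower numbers for a weaker effect. Compound 1 carries the hydrazone linker and gives 44.8%, the highest of the three numbers. Compound 2, with the closed five-membered ring and a 2,3-dimethoxyphenyl group, gives 17.5%, which stands second of the three; it lies below compound 1 and above compound 3, and both gaps are beyond the usual scatter. Compound 3, which carries a trimethoxyphenyl group on the same saturated ring carbon, gives -1.4%, the lowest number.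

Compound 4 `COc1cc(C2=NN(C(C)=O)C(c3ccc(Cl)c(Cl)c3)O2)cc(OC)c1OC` has not yet been measured. It differs from compound 2 in one place: 3,4-dichlorophenyl in place of 2,3-dimethoxyphenyl on a saturated ring carbon. Among the compounds with values here, since no single-change step between the measured compounds is available, and the only comparison on the shared core shows two low numbers, there is no firm basis for expecting a large shift in this assay; a change of no more than the scatter, in either direction, seems the most reasonable expectation.

Compound 4 is therefore estimated at 20%, with a range from 2% to 40%. The expected step from compound 2 is a number 2.5 percentage points higher from compound 2 to compound 4 (within the scatter).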

Compound 4, a percentage reported as inhibition, at one concentration (the size of the read-out at that concentration, not a potency): 3.1%
Estimate against measurement, compound 4: 16.9 percentage points above; low and high end bracket the measured number.
By their numbers in this assay, from the lowest: compounds 3 and 4 (each within the scatter of the next); then compound 2; then compound 1.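

In this assay, within the data shown here, the swap of 2,3-dimethoxyphenyl for 3,4-dichlorophenyl on the saturated ring carbon gives the first single-change step on the shared core, a number 14.4 percentage points lower from compound 2 to compound 4 (beyond the scatter), so the number does respond to the aryl group at this position. The result also shows that the mere presence of methoxy groups on this ring does not settle the outcome: compound 4 gives 3.1% and compound 3 gives -1.4%, two values within the scatter of each other, even though compound 3 carries a trimethoxyphenyl group and compound 4 a 3,4-dichlorophenyl group, while compound 2, also methoxy-bearing, stands apart at 17.5%. Nothing available here explains why this change has the effect it has.

The compounds shown leave open whether any other group at this carbon can bring the number back up, for example a plain phenyl ring, a ring bearing an amine or a ring bearing a carboxylic acid. They also leave open whether a single methoxy or a single chlorine on the ring would behave like the pairs tested here, and whether a longer chain in place of the acetyl group would change the picture.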